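The compounds below may be only part of what the source reports. "The series", "measured", "known", "first", "only" and "open" are said of these compounds alone.

Measured in a functional assay on HepG2 cells (Homo sapiens) for cytotoxicity, read by MTT assay, with a stated time of 48 h; on this read-out lower numbers stand for stronger inhibition and higher numbers for weaker inhibition:
- Compound 1 `Cc1n[nH]c2c1C(c1ccc(N(C)C)cc1)C(C(=O)NN)=C(N)N2`: 66400 nM
- Compound 2 `Cc1n[nH]c2c1C(c1ccc(N(C)C)cc1)C(C(=O)NNC(N)=S)=C(N)N2`: 6320 nM
- Compound 3 `Cc1n[nH]c2c1C(c1ccc(N(C)C)cc1)C(C(=O)n1ncc(C#N)c1N)=C(N)N2`: 66300 nM

Compound 2 has the lowest number of the three, and both gaps to it lie beyond the scatter: an 11-fold lower number from compound 1 to compound 2 (1.02 log units; beyond the scatter), and a 10-fold higher number from compound 2 to compound 3 (1.02 log units; beyond the scatter). Compound 4 `Cc1n[nH]c2c1C(c1ccc(N(C)C)cc1)C(C(=O)NNc1cc([N+](=O)[O-])ccc1[N+](=O)[O-])=C(N)N2` keeps the shared core and differs from compound 2 by a group of 12 heavy atoms (6 carbon, 2 nitrogen, 4 oxygen; one six-membered aromatic ring of carbon only) in place of a group of 3 heavy atoms (1 carbon, 1 nitrogen, 1 sulfur; no ring), on an amine nitrogen.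

Among the compounds with values here, three measured steps bear on this change. The step of an 11-fold lower number from compound 1 to compound 2 (1.02 log units; beyond the scatter) added, on that same amine nitrogen, the group that compound 4 gives up. The step of a 1.0-fold lower number from compound 1 to compound 3 (0.00 log units; within the scatter) shows that the ring-bearing compound 3 sits level with compound 1. Within the data shown here, no measured compound carries 2,5-dinitrophenyl, so its own contribution is unknown. A moderate rise in this assay is therefore expected, smaller than the large steps seen so far. The expected change is a 2.5-fold higher number from compound 2 to compound 4 (0.40 log units; beyond the scatter). For compound 4 the estimated value is 16000 nM, with an expected range from 5000 nM to 60000 nM.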

Compound 4, half-maximal inhibitory concentration: 8680 nM
Compound 4: the middle estimate sits 1.8-fold (0.27 log units) above what was measured; the measured number falls inside the stated range.
By their numbers in this assay, from the lowest: compounds 2 and 4 (each within the scatter of the next); then compounds 3 and 1 (each within the scatter of the next).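

In this assay, the lower number on this amine nitrogen is not tied to the sulfur-bearing group of compound 2: 2,5-dinitrophenyl in place of hydrogen also gives a modest step, a 7.6-fold lower number from compound 1 to compound 4 (0.88 log units; beyond the scatter). Exchanging one group for the other gives a 1.4-fold higher number from compound 2 to compound 4 (0.14 log units; within the scatter), so two groups with very different heavy-atom counts, only one of them carrying a ring, stand level at this place. Compound 3, which carries its ring on the carbonyl carbon and not on this nitrogen, does not share the drop, with a 1.0-fold lower number from compound 1 to compound 3 (0.00 log units; within the scatter). Nothing available gives a reason for these steps. From the compounds shown here alone, whether a plain phenyl ring or a phenyl ring with a single nitro group would stand level with 2,5-dinitrophenyl remains open. So does whether an oxygen in place of the sulfur of compound 2 would keep its number.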